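This account rests on a few compounds, and the source may have more. Where it says the series, first, only, none or still open, it means among the compounds named here.

Compound 1 `C1=C(c2cccnc2)CC2CNCC1C2` is the parent of this small set. In an in vitro assay on SH-SY5Y cells for displacement of a labelled ligand from Neuronal acetylcholine receptor; alpha3/beta4 (Homo sapiens) (on this read-out lower numbers stand for stronger inhibition and higher numbers for weaker inhibition), compound 1 gives 12 nM, which places it second highest of the three numbers: nearest to compound 3 `Clc1ccc(C2=CC3CNCC(C2)C3)cn1`, which gives 6.2 nM, and furthest from compound 2 `Clc1cncc(C2=CC3CNCC(C2)C3)c1`, which gives 40 nM. The two measured steps both concern a chloro in place of hydrogen on an aromatic carbon: a 3.3-fold higher number from compound 1 to compound 2 (0.52 log units; beyond the scatter) and a 1.9-fold lower number from compound 1 to compound 3 (0.29 log units; within the scatter), the first beyond the scatter, the second within it.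

Compound 4 `C1=C(c2cccnc2)C[C@@H]2CNC[C@H]1C2` differs from compound 1 in another way: the two compounds have the same atoms and bonds; at least one stereo element is drawn with a configuration in one of them and without one in the other: 2 of 2 stereo elements differ; a stereocentre at a saturated ring carbon is drawn without a configuration in compound 1 and R in compound 4; a stereocentre at a saturated ring carbon is drawn without a configuration in compound 1 and S in compound 4. Neither measured step bears on such a change, since both leave the stereocentres drawn without configuration, so the data give no direct guide. As compound 4 is one drawn configuration of the same atoms and bonds as compound 1, its number is expected to lie close to that of compound 1, with a modest downward lean and a wide range, so that a 1.3-fold lower number from compound 1 to compound 4 (0.12 log units; within the scatter) is the expected step. Compound 4 is therefore estimated at 9 nM, between 3 nM and 40 nM.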

Compound 4, inhibition constant: 23 nM
Compound 4: the middle estimate sits 2.6-fold (0.41 log units) below what was measured; the range from low to high includes it.
By their numbers in this assay, from the lowest: compounds 3, 1, 4 and 2 (each within the scatter of the next, the first and the last beyond it).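

Among the compounds shown here, compound 4 is the first compound here to change the stereocentres at the saturated ring carbons rather than the aromatic ring, and in this assay the result is a 1.9-fold higher number from compound 1 to compound 4 (0.28 log units; within the scatter). A single drawn configuration of the shared core therefore reads the same as compound 1 within the usual scatter, so the data show no separation between the drawn and undrawn forms. That comparison rests on one distinction alone: the fact that one of compounds 1 and 4 is drawn with a defined configuration and the other without, at the place where they differ.

The compounds shown leave open how the opposite drawn configuration at both stereocentres would read, and so whether the two configurations differ from each other at this receptor. They also leave open whether a drawn configuration would behave in the same way when carrying the chloro of compound 2 or compound 3, or a fluoro or methoxy group on the same aromatic ring.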